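Methoxy Substitution on Two Related Cores

The source may hold more compounds than are shown below. What is called first, only, known or untested is meant among the compounds shown, and "the series" means these compounds.

In a functional assay on L1210 cells (Mus musculus) for inhibition, read by cell counting, with a stated time of 2 days (on this read-out higher numbers stand for weaker inhibition and lower numbers for stronger inhibition), the measured compounds are:
- compound 1 `Nc1cccc(-c2cn3nc(Cc4ccccc4)sc3n2)c1` gives 7400 nM
- compound 2 `COc1ccc(Cc2nn3cc(-c4cccc(N)c4)nc3s2)cc1` gives 227000 nM
- compound 3 `Nc1cccc(-c2cn3c(-c4ccccc4)csc3n2)c1` gives 85000 nM

Compound 1 and compound 2 differ in one place, (methoxy in place of hydrogen on an aromatic carbon), and this change made a 31-fold higher number from compound 1 to compound 2 (1.49 log units; beyond the scatter). Compound 3 carries a different core; how its core differs from that of compound 1 is not broken down here, but its value in this assay sits between those of the other two, closer to compound 2 than to compound 1.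

Compound 4 `COc1ccc(-c2csc3nc(-c4cccc(N)c4)cn23)cc1` has not yet been measured. It differs from compound 3 by methoxy in place of hydrogen on an aromatic carbon, the same change that separates compound 1 from compound 2. Since the two cores differ and the change has been seen only once, the step may not repeat at the same size. Still, in this assay a step of about a 3.5-fold higher number from compound 3 to compound 4 (0.55 log units; beyond the scatter) is expected from compound 3 to compound 4, resting on the step of a 31-fold higher number from compound 1 to compound 2 (1.49 log units; beyond the scatter) seen on the other core. Compound 4 is therefore estimated at 300000 nM in this assay, with a likely range from 60000 nM to 1500000 nM.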

Compound 4, half-maximal inhibitory concentration: 19000 nM
Compound 4: middle estimate off by 16-fold (1.20 log units), on the high side; the measured number lies below the stated range.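

On the core of compound 3, methoxy in place of hydrogen gave a 4.5-fold lower number from compound 3 to compound 4 (0.65 log units; beyond the scatter) in this assay and so went with stronger inhibition, whereas on the core of compound 1 the same change went with weaker inhibition. Set side by side, the two results point in opposite directions: the same change on two cores in this assay, a 31-fold higher number (1.49 log units; beyond the scatter) from compound 1 to compound 2 and a 4.5-fold lower number (0.65 log units; beyond the scatter) from compound 3 to compound 4, 140-fold (2.14 log units) apart, beyond the scatter of two such steps.
This shows that, in this series, the effect of adding the methoxy on one core cannot simply be carried over to another core. It does not show why the two cores respond differently or what a third core would do, since each direction rests on a single pair of compounds.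

The compounds shown carry only hydrogen or methoxy at this place on the aromatic ring, so it remains open how an ethoxy group, a hydroxyl group or a chlorine atom would behave there on either core. On these data alone, it also remains open whether the opposite steps would appear on other cores.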